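Aryl swap on the shared core: weak growth inhibition throughout

The compounds below may be only part of what the source reports. "The series", "measured", "known", "first", "only" and "open" are said of these compounds alone.

Compound 3 `O=C(/C(=C\c1c(O)cc(O)cc1O)Sc1ccc(Br)cc1)c1ccc(Cl)cc1` gives 50000 nM in a functional assay on DU-145 cells (Homo sapiens) for inhibition, read by trypan blue exclusion, with a stated time of 96 h (on this read-out lower numbers stand for stronger inhibition of growth and higher numbers for weaker inhibition of growth), level with compound 2 `COc1ccc(/C=C(/Sc2ccc(Br)cc2)C(=O)c2ccc(Cl)cc2)cc1`, which gives 50000 nM in this assay. Compound 1 `CN(C)c1ccc(/C=C(/Sc2ccc(Br)cc2)C(=O)c2ccc(Cl)cc2)cc1` returns only a limit, > 100000 nM, in this assay, as shown by the limit of > 100000 nM in this assay, at which 1 of the 3 values shown sits. The steps of an at least 2.0-fold lower number from compound 1 to compound 2 (0.30 log units; that floor lies within the scatter) and an at least 2.0-fold lower number from compound 1 to compound 3 (0.30 log units; that floor lies within the scatter) start from that limit and so are floors only. Within the data shown here, the step of no change at the digits printed from compound 2 to compound 3 (within the scatter) is the one that exchanges the aryl group on the double-bonded chain carbon, and it is flat. Compound 4 `O=C(/C(=C\c1ccc(F)cc1F)Sc1ccc(Br)cc1)c1ccc(Cl)cc1` makes the same kind of exchange: 2,4-difluorophenyl in place of 2,4,6-trihydroxyphenyl on a double-bonded chain carbon bound to a double-bonded chain carbon. Among the measured compounds shown here, with the only comparable aryl swap showing no change, a step of no change at the digits printed from compound 3 to compound 4 (within the scatter) is expected, that is, none beyond the scatter. Compound 4 is estimated at 50000 nM, within 15000 nM to 150000 nM. A limit-only reading for compound 4 also remains possible.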

Compound 4, concentration for 50% growth inhibition: 1000 nM
The estimate for compound 4 lay 50-fold (1.70 log units) above the measured number; the whole stated range lies above it.
By their numbers in this assay, from the lowest: compound 4; then compounds 2 and 3 (each within the scatter of the next). At a limit, above all of these: compound 1.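

The exchange at this position gives a 50-fold lower number from compound 3 to compound 4 (1.70 log units; beyond the scatter) and a 50-fold lower number from compound 2 to compound 4 (1.70 log units; beyond the scatter) in growth inhibition, so the aryl group on the double-bonded chain carbon can move the read-out well beyond the scatter, which the flat step between compound 2 and compound 3 did not show. Of the aryl groups shown, only 2,4-difluorophenyl does this. Compound 1 returns only a limit, so an at least 100-fold lower number from compound 1 to compound 4 (2.00 log units; beyond the scatter) is a floor: the limit of > 100000 nM in this assay, at which 1 of the 4 values shown sits.

Which feature of 2,4-difluorophenyl carries the gain stays open. Going by these compounds, whether a single fluorine, a trifluoromethyl or a nitrile on the same ring would hold this level also stays open.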